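This account rests on a few compounds, and the source may have more. Where it says the series, first, only, none or still open, it means among the compounds named here.

Working notes on the thiophene-free description: three amides sharing the core of compound 1 `CCC(=O)Nc1sc2c(c1C#N)CCCC2` have been run in a functional assay on RKE cells for antagonist activity at Vasoactive intestinal polypeptide receptor 1 (Rattus norvegicus), read by HTRF and cAMP accumulation, with stated times of 10 min and 30 min; a lower number here means a stronger inhibitor, a higher number a weaker inhibitor. Compound 1 gives 12000 nM, compound 2 `CC(C)C(=O)Nc1sc2c(c1C#N)CCCC2` gives 3400 nM, and compound 3 `N#Cc1c(NC(=O)C2CC2)sc2c1CCCC2` gives 2700 nM. Compound 3 carries the lowest number of the three, but its separation from compound 2 is only a 1.3-fold lower number from compound 2 to compound 3 (0.10 log units; within the scatter), which stays within the scatter, so the two cannot be ordered; only compound 1 is clearly apart, by a 4.4-fold lower number from compound 1 to compound 3 (0.65 log units; beyond the scatter) and by a 3.5-fold lower number from compound 1 to compound 2 (0.55 log units; beyond the scatter).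

Compound 4 `N#Cc1c(NC(=O)C2CCC2)sc2c1CCCC2` is not yet measured. It differs from compound 3 by cyclobutyl in place of cyclopropyl on a carbonyl carbon. Within the data shown here, the steps that bear on it are those that vary the group on the carbonyl carbon: moving from ethyl to cyclopropyl gave a 4.4-fold lower number from compound 1 to compound 3 (0.65 log units; beyond the scatter), while cyclopropyl against isopropyl gave a 1.3-fold lower number from compound 2 to compound 3 (0.10 log units; within the scatter), no difference beyond the scatter. A step to a second cycloalkyl is therefore expected to be small in this assay, with no clear direction; the expected step is a 1.2-fold lower number from compound 3 to compound 4 (0.09 log units; within the scatter). Compound 4 is estimated at 2200 nM, within a range of 700 nM to 7000 nM.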

Compound 4, half-maximal inhibitory concentration: 1800 nM
Compound 4: the middle estimate sits 1.2-fold (0.09 log units) above what was measured, and the stated range covers the measured number.
By their numbers in this assay, from the lowest: compounds 4, 3 and 2 (each within the scatter of the next); then compound 1.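

Cyclobutyl on the carbonyl carbon cannot be separated from cyclopropyl (a 1.5-fold lower number from compound 3 to compound 4 (0.18 log units; within the scatter)) or from isopropyl (a 1.9-fold lower number from compound 2 to compound 4 (0.28 log units; within the scatter)) in this assay, so adding one carbon to the ring gives no readable change at this position. Against ethyl the step is beyond the scatter (a 6.7-fold lower number from compound 1 to compound 4 (0.82 log units; beyond the scatter)), which makes cyclobutyl the third group, after isopropyl and cyclopropyl, to stand clearly apart from compound 1, and none of the compounds shown goes against this. (Nothing available explains these differences).

On these data alone, whether a cyclopentyl or cyclohexyl ring on the carbonyl carbon would stay level with compound 4 or move away from it remains open. So does the effect of a phenyl ring, a longer chain or an amine at this place, and of any change to the nitrile or the shared core.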